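This account rests on a few compounds, and the source may have more. Where it says the series, first, only, none or still open, it means among the compounds named here.

Measured compounds:
compound 1, `O=C(CSc1nc(Nc2ccccc2)c2ccccc2n1)Nc1ccccc1F`, 12400 nM;
compound 2, `O=C(CSc1nc(Nc2ccccc2)c2ccccc2n1)Nc1cccc(F)c1`, 15600 nM;
compound 3, `C=CC(=O)Nc1cccc(NC(=O)CSc2nc(Nc3ccccc3)c3ccccc3n2)c1`, 8740 nM.

In a functional assay on PC-3 cells (Homo sapiens) for inhibition, read by MTT assay, with a stated time of 72 h (a higher number here means a weaker inhibitor, a lower number a stronger inhibitor), compound 2 carries the highest number of the three, but its steps to the others stay within the scatter, so all three stand level. Compound 4, `O=C(CSc1nc(Nc2ccccc2)c2ccccc2n1)Nc1ccc(Cl)c(Cl)c1`, differs from compound 2 by 3,4-dichlorophenyl in place of 3-fluorophenyl on an amide-type nitrogen. Among the compounds with values here, the steps that bear on this change all exchange the group on the amide-type nitrogen: a 1.3-fold higher number from compound 1 to compound 2 (0.10 log units; within the scatter), a 1.4-fold lower number from compound 1 to compound 3 (0.15 log units; within the scatter) and a 1.8-fold lower number from compound 2 to compound 3 (0.25 log units; within the scatter), none of them beyond the scatter. Within the data shown here, for 3,4-dichlorophenyl itself there is no measured precedent. Compound 4 is therefore expected to show a step of a 1.4-fold lower number from compound 2 to compound 4 (0.15 log units; within the scatter), nothing beyond the scatter. Compound 4 is estimated at 11000 nM in this assay, within 5000 nM to 25000 nM.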

Compound 4, half-maximal inhibitory concentration: 12100 nM
Beside the measured number, compound 4's estimate is 1.1-fold (0.04 log units) below it; the measured number falls inside the stated range.
By their numbers in this assay, from the lowest: compounds 3, 4, 1 and 2 (each within the scatter of the next).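

In this assay, 3,4-dichlorophenyl brings two chlorine atoms onto the amide-type nitrogen's phenyl group, yet the numbers stay level: a 1.3-fold lower number from compound 2 to compound 4 (0.11 log units; within the scatter), a 1.0-fold lower number from compound 1 to compound 4 (0.01 log units; within the scatter) and a 1.4-fold higher number from compound 3 to compound 4 (0.14 log units; within the scatter). Across these four compounds, then, this position shows no step beyond the scatter, now including a change from one halogen to two. No evidence at hand explains this result.

From the compounds shown here alone, it remains open whether a carboxylic acid or an amine on this phenyl group, or a longer alkyl chain in its place, would move the number beyond the scatter.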